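The source may hold more compounds than are shown below. What is called first, only, known or untested is meant among the compounds shown, and "the series" means these compounds.

Measured so far, in a functional assay for agonist activity at G protein-coupled receptor 88 (Homo sapiens), read by HTRF and cAMP accumulation; a lower number here means that less compound is needed, a higher number that more compound is needed for the effect:
- compound 1, `CC[C@H](C)[C@H](N)CN(C(=O)[C@@H]1C[C@H]1c1ccccc1Cl)c1ccc(-c2ccccc2)cc1`: > 25000 nM, a limit of this assay and not a number.
- compound 2, `CC[C@H](C)[C@H](N)CN(C(=O)[C@@H]1C[C@H]1c1cc(F)cc(F)c1)c1ccc(-c2ccccc2)cc1`: 960 nM.
- compound 3, `CC[C@H](C)[C@H](N)CN(C(=O)[C@@H]1C[C@H]1c1ccoc1)c1ccc(-c2ccccc2)cc1`: 580 nM.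

Compound 3 holds the lowest of the two numbers in this assay; its nearest neighbour is compound 2, and the step of a 1.7-fold lower number from compound 2 to compound 3 (0.22 log units; within the scatter) stays within the scatter. Compound 1 sits at the limit (the limit of > 25000 nM in this assay, at which 1 of the 3 values shown sits), so the steps of an at least 26-fold lower number from compound 1 to compound 2 (1.41 log units; beyond the scatter) and an at least 43-fold lower number from compound 1 to compound 3 (1.63 log units; beyond the scatter) can only be given as floors, yet both are large.

Compound 4, `CC[C@H](C)[C@H](N)CN(C(=O)[C@@H]1C[C@H]1c1nc(C)c(C)s1)c1ccc(-c2ccccc2)cc1`, takes the change (4,5-dimethyl-1,3-thiazol-2-yl in place of furan-3-yl on a saturated ring carbon). Within the data shown here, of the measured steps, only the swap of one five-membered aromatic ring for the 3,5-difluorophenyl in a 1.7-fold lower number from compound 2 to compound 3 (0.22 log units; within the scatter) touches this position directly, and it lies within the scatter; no measured step involves 4,5-dimethyl-1,3-thiazol-2-yl. The estimate for compound 4 in this assay is therefore a step of a 1.6-fold higher number from compound 3 to compound 4 (0.19 log units; within the scatter) that is expected to stay near the scatter, with a wide range to allow for the untested group: compound 4 is expected at 900 nM, between 250 nM and 3500 nM.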

Compound 4, half-maximal effective concentration: 3600 nM
The estimate for compound 4 lay 4.0-fold (0.60 log units) below the measured number; measured number outside the range, above it.
By their numbers in this assay, from the lowest: compounds 3 and 2 (each within the scatter of the next); then compound 4. At a limit, above all of these: compound 1.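

In this assay, the swap between furan-3-yl and 3,5-difluorophenyl on this saturated ring carbon had stayed within the scatter, but 4,5-dimethyl-1,3-thiazol-2-yl gives a 6.2-fold higher number from compound 3 to compound 4 (0.79 log units; beyond the scatter) and a 3.8-fold higher number from compound 2 to compound 4 (0.57 log units; beyond the scatter), so not every aromatic ring at this position reads alike. The step of an at least 6.9-fold lower number from compound 1 to compound 4 (0.84 log units; beyond the scatter) still places this group clearly apart from the 2-chlorophenyl of compound 1, which makes the spread at this position graded across the ring groups shown rather than all or nothing. That step is only a floor, since the value of compound 1 is a limit and not a number: the limit of > 25000 nM in this assay, at which 1 of the 4 values shown sits.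

As far as these compounds go, whether the higher number of compound 4 goes with the ring hetero atoms or with the methyl groups stays open, and a plain 1,3-thiazol-2-yl would separate the two. From the compounds shown here alone, how a carboxylic acid or an amine on the ring at this position would read also stays open.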